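Adding a Methyl on the Enamide Chain: A Small Step

The source may hold more compounds than are shown below. What is called first, only, known or untested is meant among the compounds shown, and "the series" means these compounds.

Compound 2 `CC/C=C/C(=O)Nc1cc2c(N3CCCc4ccccc43)ncnc2cc1OC` and compound 1 `COc1cc2ncnc(N3CCc4ccccc43)c2cc1NC(=O)/C=C/C(C)C` were both tested in a functional assay on PC-3 cells (Homo sapiens) for antiproliferative activity, read by MTT assay, with a stated time of 72 h; a lower number here means a stronger inhibitor, a higher number a weaker inhibitor. Compound 2 gives 6310 nM, the lowest of the two numbers shown. Compound 1 gives 6530 nM, and the two values sit within the usual scatter of each other, so nothing can be read into their order. Compound 3 `COc1cc2ncnc(N3CCCc4ccccc43)c2cc1NC(=O)/C=C/C(C)C` has not yet been measured. It differs from compound 2 in one place: methyl in place of hydrogen on a saturated chain carbon bound to a double-bonded chain carbon and a saturated chain carbon. For the measured compounds named here, with no measured pair showing this change, the expectation can rest only on the two numbers in hand, which sit close together despite differences elsewhere in the molecule. For compound 3, therefore, no step beyond the scatter is expected in this assay, in either direction. The expected step of a 1.0-fold higher number from compound 2 to compound 3 (0.01 log units; within the scatter) is thus essentially flat. Compound 3 is estimated at 6500 nM, with a likely range from 3500 nM to 12000 nM.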

Compound 3, half-maximal inhibitory concentration: 8430 nM
The estimate for compound 3 lay 1.3-fold (0.11 log units) below the measured number, within the range that was stated.
By their numbers in this assay, from the lowest: compounds 2, 1 and 3 (each within the scatter of the next).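

In this assay, for the compounds shown here, the pair compound 2 and compound 3 gives the first direct reading of methyl in place of hydrogen on this saturated chain carbon, the change from ethyl to isopropyl: a 1.3-fold higher number from compound 2 to compound 3 (0.13 log units; within the scatter) shows that this single added carbon has no readable effect on the number. The second single change, 1,2,3,4-tetrahydroquinolin-1-yl in place of 2,3-dihydro-1H-indol-1-yl on an aromatic carbon, gives a 1.3-fold higher number from compound 1 to compound 3 (0.11 log units; within the scatter) and likewise cannot be read as a real difference. Nothing available explains either result.

Going by these compounds, whether a tert-butyl group or a longer chain at this place would move the number beyond the scatter remains open. So does the effect of an amine, such as dimethylamino, on the same chain carbon.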